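From Compound 3 to Compound 4: One More Chloro

The source may report more compounds than this note shows. Statements on the series, on what has been measured and on what is new or still open speak of the compounds shown alone.

In an ADME assay on H9c2 cells (Rattus norvegicus) for cytotoxicity, read by resazurin assay, with a stated time of 72 h (on this read-out higher numbers stand for lower toxicity in this test and lower numbers for higher toxicity in this test), compound 1 `C/C(=N\Nc1nc(-c2ccncc2)cs1)c1ccc(Cl)c(Cl)c1` gives 41900 nM. Compound 2 `C/C(=N\Nc1nc(-c2ccc(Cl)cc2Cl)cs1)c1ccc(Cl)c(Cl)c1` returns only a limit of the assay, > 50000 nM. Compound 3 `C/C(=N\Nc1nc(-c2ccc(Cl)c(Cl)c2)cs1)c1ccc(Cl)c(Cl)c1` also returns only a limit, > 50000 nM, so it has no exact number. Compound 4 `C/C(=N\Nc1nc(-c2ccc(Cl)c(Cl)c2Cl)cs1)c1ccc(Cl)c(Cl)c1` differs from it by chloro in place of hydrogen on an aromatic carbon, a chloro in place of hydrogen on an aromatic carbon, ortho to a chloro group. Among the compounds with values here, no measured step makes this exact change. The nearest are an at least 1.1-fold higher number from compound 1 to compound 2 (0.07 log units; that floor lies within the scatter) and an at least 1.1-fold higher number from compound 1 to compound 3 (0.07 log units; that floor lies within the scatter), both swaps of pyridin-4-yl for a dichlorophenyl group, while a step that the two limits leave unreadable from compound 2 to compound 3. No step beyond the scatter is therefore expected, and the estimated step is a step that the limit leaves unreadable from compound 3 to compound 4. For compound 4 the expected value is 55000 nM, with an estimated range of 25000 nM to 120000 nM.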

Compound 4, half-maximal cytotoxic concentration: 17000 nM
The estimate for compound 4 lay 3.2-fold (0.51 log units) above the measured number; the measured number lies below the stated range.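

The added chloro, ortho to a chloro group, gives the first step among these compounds that lies beyond the scatter in this assay, with an at least 2.9-fold lower number from compound 3 to compound 4 (0.46 log units; beyond the scatter), which means higher toxicity in this test. The same compound is also reached from the 2,4-dichlorophenyl compound, with an at least 2.9-fold lower number from compound 2 to compound 4 (0.46 log units; beyond the scatter). Both sizes are only floors, because compound 2 and compound 3 each rest on a limit: the limit of > 50000 nM in this assay, at which 2 of the 4 values shown sit.

On these data alone, whether a methyl or methoxy group on that carbon would give a similar step stays open.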